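Estimating Compound 4 from Three Measured Analogues

This account rests on a few compounds, and the source may have more. Where it says the series, first, only, none or still open, it means among the compounds named here.

Three compounds share one core and differ only in the group on an amine nitrogen in a ring. In a functional assay on A549 cells (Homo sapiens) for antiproliferative activity, read by MTT assay, with a stated time of 72 h (a lower number here means a stronger inhibitor, a higher number a weaker inhibitor), compound 1 `Nc1nc(N)c2cc(CSC(=S)N3CCN(C4CCCCC4)CC3)ccc2n1` gives 4710 nM, compound 2 `Nc1nc(N)c2cc(CSC(=S)N3CCN(c4ccc(O)cc4)CC3)ccc2n1` gives 4210 nM, and compound 3 `Nc1nc(N)c2cc(CSC(=S)N3CCN(c4ccc(F)cc4)CC3)ccc2n1` gives 2040 nM. Compound 2 sits close to compound 1, within the scatter, while its gap to compound 3 lies beyond it. Compound 4 `Nc1nc(N)c2cc(CSC(=S)N3CCN(c4ccc(F)cc4F)CC3)ccc2n1` differs from compound 2 by 2,4-difluorophenyl in place of 4-hydroxyphenyl on an amine nitrogen in a ring. For the measured compounds named here, the steps that bear on this change are a 2.1-fold lower number from compound 2 to compound 3 (0.31 log units; beyond the scatter) and a 2.3-fold lower number from compound 1 to compound 3 (0.36 log units; beyond the scatter), both modest and toward lower numbers. A similar modest step toward a lower number is expected here, a 2.1-fold lower number from compound 2 to compound 4 (0.32 log units; beyond the scatter). Compound 4 is therefore estimated at 2000 nM, within a range of 900 nM to 4500 nM.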

Compound 4, half-maximal inhibitory concentration: 5120 nM
Compound 4: the middle estimate sits 2.6-fold (0.41 log units) below what was measured; the measured number lies above the stated range.
By their numbers in this assay, from the lowest: compound 3; then compounds 2, 1 and 4 (each within the scatter of the next).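

A second fluoro on the aromatic ring does not extend the lower number of compound 3 in this assay but reverses it (a 2.5-fold higher number from compound 3 to compound 4 (0.40 log units; beyond the scatter)). The 2,4-difluorophenyl group stays within the scatter of both 4-hydroxyphenyl (a 1.2-fold higher number from compound 2 to compound 4 (0.08 log units; within the scatter)) and cyclohexyl (a 1.1-fold higher number from compound 1 to compound 4 (0.04 log units; within the scatter)), so among these groups only the 4-fluorophenyl of compound 3 stands apart. No measurement shown gives a reason for this. Going by these compounds, it remains open whether the lower number of compound 3 is specific to fluoro or would also appear with chloro, methoxy or an amine on that aromatic carbon.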